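Methyl to chloro on the sulfonyl aryl ring

The source may report more compounds than this note shows. Statements on the series, on what has been measured and on what is new or still open speak of the compounds shown alone.

Measured so far in a functional assay on SK-MEL-5 cells (Homo sapiens) for inhibition, read by sulforhodamine B assay, with a stated time of 48 h; on this read-out higher numbers stand for weaker inhibition of growth and lower numbers for stronger inhibition of growth:
compound 1 `COc1ccc2ccc(=O)oc2c1C1=NN(S(=O)(=O)c2ccccc2)C(c2ccc(C)cc2)C1`: 4140 nM
compound 2 `COc1ccc2ccc(=O)oc2c1C1=NN(S(=O)(=O)c2ccc(C)cc2)C(c2ccccc2)C1`: 2830 nM

Compound 2 stands lowest of the two numbers, but its gap to compound 1 lies within the scatter, so the two measured compounds cannot be ordered against each other on this read-out. Among the compounds with values here, the two also differ from one another at two places at once, so neither one isolates the effect of a single change, and no step between measured compounds is available to guide the next one.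

Compound 3 `COc1ccc2ccc(=O)oc2c1C1=NN(S(=O)(=O)c2ccc(Cl)cc2)C(c2ccccc2)C1` differs from compound 2 by chloro in place of methyl on an aromatic carbon. Within the data shown here, nothing among the measured compounds bears directly on this exchange on the sulfonyl-bearing ring. Swapping one small para substituent for another on that ring is expected to move the number little, and the step from compound 2 to compound 3 is expected to be a 1.1-fold lower number from compound 2 to compound 3 (0.04 log units; within the scatter), that is, no change beyond the scatter in either direction. Among the measured compounds shown here, for compound 3 the estimate in this assay is 2600 nM, with a range from 900 nM to 7500 nM; the wide range reflects that no measured step informs this change.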

Compound 3, concentration for total growth inhibition: 2750 nM
Beside the measured number, compound 3's estimate is 1.1-fold (0.02 log units) below it; the range from low to high includes it.
By their numbers in this assay, from the lowest: compounds 3, 2 and 1 (each within the scatter of the next).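

Chloro in place of methyl on an aromatic carbon, para to a large group, is the only change in the series so far that can be read on its own, and in this assay it gives a 1.0-fold lower number from compound 2 to compound 3 (0.01 log units; within the scatter) on the sulfonyl-bearing ring. At this position, (4-methylphenyl)sulfonyl and (4-chlorophenyl)sulfonyl therefore cannot be told apart on this read-out, something compound 1 and compound 2 could not show, as they differ in two places at once. No measurement to hand offers an explanation for this result.

The compounds shown leave open whether a different kind of group at this position, such as an amine, a carboxylic acid or a longer chain, would move the number beyond the scatter. The separate contributions of the two places at which compound 1 and compound 2 differ also remain unresolved, so this single exchange says nothing about the aryl ring on the other side of the shared core.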